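The compounds below may be only part of what the source reports. "The series", "measured", "known", "first", "only" and "open" are said of these compounds alone.

Three compounds have been measured in a physicochemical assay for lipophilicity; on this read-out higher numbers stand for higher lipophilicity and lower numbers for lower lipophilicity:

compound 1, `COc1ccc(C2=N[C@@H](C(=O)O)CS2)c(O)c1`: -0.89
compound 2, `COc1ccc(C2=N[C@@](C)(C(=O)O)CS2)c(O)c1OC`: -0.95
compound 3, `COc1ccc(C2=N[C@@](C)(C(=O)O)CS2)c(O)c1`: -0.7

Compound 2 and compound 3 differ in one place, (methoxy in place of hydrogen on an aromatic carbon), and the step in this assay was a number 0.25 log units lower from compound 3 to compound 2 (within the scatter). Compound 1 and compound 3 share much, but the difference between the two cores is not broken down here. Compound 4, `COc1ccc(C2=N[C@@H](C(=O)O)CS2)c(O)c1OC`, has not yet been measured; it differs from compound 1 by methoxy in place of hydrogen on an aromatic carbon. The surroundings are not identical, the new group being meta to a group of 8 heavy atoms rather than 9, so this is the same kind of change, not the same one. The step from compound 1 to compound 4 is expected to be a number 0.25 log units lower from compound 1 to compound 4 (within the scatter), resting on the step of a number 0.25 log units lower from compound 3 to compound 2 (within the scatter). Compound 4 is therefore estimated at -1.14, between -1.5 and -0.8.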

Compound 4, partition coefficient: -1.28
For compound 4 the middle estimate is 0.14 log units above the measured one, and the stated range covers the measured number.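

In this assay, methoxy in place of hydrogen on an aromatic carbon gives a number 0.39 log units lower from compound 1 to compound 4 (beyond the scatter) and, on the other core, a number 0.25 log units lower from compound 3 to compound 2 (within the scatter). For the compounds shown here, only the step on the core of compound 1 stands clear of the scatter, and the step on the other core does not contradict it, but two pairs are too few to show that this change carries over as a rule from one core to another. Nothing measured here says why the step has this size.

The compounds shown leave open how an amine or a longer chain such as ethoxy would behave on that aromatic carbon. They also leave open whether methoxy would give a similar step on any further core.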